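A few compounds are considered here, and "the series" means these few. Any claim that something is new, unique, unknown or untested is made for them only; others in the source may bear on it.

In a functional assay on DU-145 cells (Homo sapiens) for cytotoxicity, read by trypan blue exclusion, with a stated time of 96 h (a higher number here means a weaker inhibitor, a lower number a stronger inhibitor), compound 1 (`COc1ccc(CS(=O)(=O)/C=C/c2c(OC)cccc2OC)c([N+](=O)[O-])c1`) gives 50000 nM as its half-maximal inhibitory concentration. In the same test compound 2 (`COC(=O)CCNc1cc(CS(=O)(=O)/C=C/c2c(OC)cc(OC)cc2OC)ccc1OC`) gives 1500 nM and so holds the lower of the two numbers, which makes it the stronger inhibitor of the pair by a gap beyond the usual scatter. These two compounds differ in more than one place, so their gap says little about any single change.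

Compound 3 (`COC(=O)C(Nc1cc(CS(=O)(=O)/C=C/c2c(OC)cc(OC)cc2OC)ccc1OC)c1ccc(Cl)cc1`) has not yet been measured. It differs from compound 2 in one place, with (4-chlorophenyl)(methoxycarbonyl)methyl in place of 2-(methoxycarbonyl)ethyl on a nitrogen on an aromatic ring as the counted change. Both groups carry a methoxycarbonyl, while the entering one also brings a six-membered aromatic ring of carbon only and a chlorine.

For the measured compounds named here, no measured pair shows what this swap does, so the data offer no firm direction. The expected change is small, within the scatter, and the estimate is a 1.3-fold lower number from compound 2 to compound 3 (0.10 log units; within the scatter) as a best guess. For compound 3 the estimated value is 1200 nM with an expected range from 200 nM to 8000 nM in this test.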

Compound 3, half-maximal inhibitory concentration: 400 nM
Compound 3: middle estimate off by 3.0-fold (0.48 log units), on the high side; the range from low to high includes it.
By their numbers in this assay, from the lowest: compound 3; then compound 2; then compound 1.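

For the compounds shown here, putting (4-chlorophenyl)(methoxycarbonyl)methyl in place of 2-(methoxycarbonyl)ethyl gives a 3.8-fold lower number from compound 2 to compound 3 (0.57 log units; beyond the scatter) in this assay, the first change in one place that can be read here. It shows that the group on this nitrogen on an aromatic ring affects the number, and that a larger group, which keeps the methoxycarbonyl and adds a six-membered aromatic ring of carbon only and a chlorine, goes with a stronger inhibitor in this pair. Nothing available explains the cause of this step.

This one swap alters the chain, the aromatic ring and the chlorine together, so it cannot show which of these parts accounts for the lower number; a plain phenyl without the chlorine, or a fluorine in the chlorine's place, would begin to separate them. The compounds shown also leave open what the methoxycarbonyl contributes, a question that a carboxylic acid or a primary amide in its place could address.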